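Working notes: from compound 1 to compound 4

A few compounds are considered here, and "the series" means these few. Any claim that something is new, unique, unknown or untested is made for them only; others in the source may bear on it.

Measured in a physicochemical assay for solubility, read by HPLC, with a stated time of 4 h, at pH 7; a lower number here means a less soluble compound, a higher number a more soluble compound:
- compound 1 `C[C@]1(COc2ccc(N3CCN(S(=O)(=O)c4ccc(C(F)(F)F)cc4)CC3)cc2)Cn2cc([N+](=O)[O-])nc2O1`: < 1 ug/mL, a limit
- compound 2 `C[C@]1(COc2ccc(-n3cc(COc4ccc(OC(F)(F)F)cc4)nn3)cc2)Cn2cc([N+](=O)[O-])nc2O1`: < 1 ug/mL, a limit
- compound 3 `C[C@]1(COc2ccc(NC(=O)Nc3ccc(Cl)cc3)cc2)Cn2cc([N+](=O)[O-])nc2O1`: 6.66 ug/mL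

Compound 1 has no number in this assay, only a limit, < 1 ug/mL. It stands at the limit of < 1 ug/mL in this assay, at which 2 of the 3 values shown sit.

Compound 4 `Cc1ccc(S(=O)(=O)N2CCN(c3ccc(OC[C@@]4(C)Cn5cc([N+](=O)[O-])nc5O4)cc3)CC2)cc1` differs from it by methyl in place of trifluoromethyl on an aromatic carbon, para to a large group.

For the measured compounds named here, no measured pair differs in one place, so the expectation starts from the limit of compound 1, < 1 ug/mL. A small upward step at most is expected, with none beyond the scatter the likeliest outcome. The estimated step is a number no lower from compound 1 to compound 4 (the limit leaves the size open). The expected value for compound 4 is 1 ug/mL, within an estimated range of 0.3 ug/mL to 4 ug/mL.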

Compound 4, solubility: < 1 ug/mL
Compound 4 gave a limit, no number (the forecaster's own chance of this, stated with the estimate: 65%); the middle value lies on the limit itself.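

For the compounds shown here, compound 1 and compound 4 both gave limits rather than numbers, so no step between them can be read: the limit of < 1 ug/mL in this assay, at which 3 of the 4 values shown sit. The compounds shown leave open whether methyl in place of trifluoromethyl on an aromatic carbon changes solubility at all.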